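A few compounds are considered here, and "the series" means these few. Any claim that something is new, unique, unknown or untested is made for them only; others in the source may bear on it.

In a functional assay on CHO cells for agonist activity at Alpha-1A adrenergic receptor (Homo sapiens), read by FLIPR and calcium flux (a lower number here means a smaller maximal response, a higher number a larger maximal response), the three measured compounds give:

Compound 1 `COc1c(C)ccc2c1CCC2c1ncc[nH]1`: 40%
Compound 2 `COc1cccc2c1CCC2c1ncc[nH]1`: 65%
Compound 3 `CNC(=O)c1cccc2c1CCC2c1ncc[nH]1`: 59%

Compound 1 stands lowest of the three; compound 3 is nearest and compound 2 furthest, and both gaps lie beyond the scatter. Removing the methyl gave a number 25 percentage points higher from compound 1 to compound 2 (beyond the scatter). Exchanging the methoxy for a methylcarbamoyl gave a number 6 percentage points lower from compound 2 to compound 3 (within the scatter), a step within the scatter.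

Compound 4 `Cc1ccc2c(c1NS(C)(=O)=O)CCC2c1ncc[nH]1` differs from compound 1 in one place: methanesulfonamido in place of methoxy on an aromatic carbon. Going by the values given here, the only step that bears on it, the exchange of methoxy in a number 6 percentage points lower from compound 2 to compound 3 (within the scatter), was small, and no measured step involves methanesulfonamido. Compound 4 is therefore expected near 42%, between 25% and 60%. This estimate means an expected step of a number 2 percentage points higher from compound 1 to compound 4 (within the scatter), within the scatter.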

Compound 4, largest response reached (Emax), in percent of the reference or control that the assay uses: 83%
Compound 4: the middle estimate sits 41 percentage points below what was measured; the measured number lies above the stated range.
By their numbers in this assay, from the lowest: compound 1; then compounds 3 and 2 (each within the scatter of the next); then compound 4.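

In this assay the exchange of methoxy for methanesulfonamido, ortho to a methyl group, gave a number 43 percentage points higher from compound 1 to compound 4 (beyond the scatter) and so shows that the response is sensitive to the group at this position. Going by these compounds alone, the only earlier exchange of methoxy, for methylcarbamoyl in a compound without that methyl group, gave a number 6 percentage points lower from compound 2 to compound 3 (within the scatter) and showed no such sensitivity. No available evidence accounts for the size of the new step.

Going by these compounds, whether an amine or a carboxylic acid at this position would give a similar response remains open. So does the effect of methanesulfonamido on the core without the methyl group.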